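Swapping an Ester for an Alcohol on a Dehydrogenase Inhibitor

The source may hold more compounds than are shown below. What is called first, only, known or untested is meant among the compounds shown, and "the series" means these compounds.

Compound 1, `CCCC[S+]([O-])c1sc2nc(-c3nccs3)cc(-c3ccc(C(=O)OC)cc3)c2c1N`, gives 15.1 nM.
Compound 2, `CCOC(=O)c1sc2nc(-c3cccs3)cc(-c3ccccc3)c2c1N`, gives > 7500 nM.
Compound 3, `CCCC[S+]([O-])c1sc2nc(-c3nccn3C)nc(-c3ccccc3)c2c1N`, gives 3.7 nM.

All three were tested in an assay for inhibition of 15-hydroxyprostaglandin dehydrogenase [NAD(+)] (Homo sapiens), read by fluorescence, with a stated time of 15 min, in the presence of a further agent that is not named here; a lower number here means a stronger inhibitor, a higher number a weaker inhibitor. Of the two numbers recorded, compound 1 has the higher one; compound 3 gives a lower number, and the gap between them lies beyond the usual scatter, so compound 3 is the stronger inhibitor of the two. Compound 2 sits at the limit of > 7500 nM in this assay, at which 1 of the 3 values shown sits, so no number is known for it, only that it is a weak inhibitor.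

The step followed here leads from compound 1 to compound 4, `CCCC[S+]([O-])c1sc2nc(-c3nccs3)cc(-c3ccc(CO)cc3)c2c1N`. The two differ in one place: hydroxymethyl in place of methoxycarbonyl on an aromatic carbon. For the measured compounds named here, no pair of measured compounds differs in this way, so the size of the step is open. The ester and the alcohol are both small, uncharged groups sitting para to a large group on the phenyl ring, and a change of that kind is expected to shift the number only modestly, if at all, in this assay .

For compound 4 the expected step is a 1.7-fold higher number from compound 1 to compound 4 (0.22 log units; within the scatter), a small weakening that may still fall within the scatter. Compound 4 is therefore estimated at 25 nM, with a likely range from 8 nM to 80 nM.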

Compound 4, half-maximal inhibitory concentration: 2.5 nM
Compound 4: middle estimate off by 10-fold (1.00 log units), on the high side; the whole stated range lies above it.
By their numbers in this assay, from the lowest: compounds 4 and 3 (each within the scatter of the next); then compound 1. At a limit, above all of these: compound 2.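

Before this pair, none of the compounds shown tested what a change to the group on this phenyl ring does. No two of them differed there alone. In this assay, putting hydroxymethyl in place of methoxycarbonyl gives a 6.0-fold lower number from compound 1 to compound 4 (0.78 log units; beyond the scatter), so the group at this position clearly affects the reading, and the change leads to stronger inhibition. Within this pair, then, the ester is not needed for strong inhibition, and a smaller group that carries a hydrogen-bond donor is more than tolerated at this place on the ring.

Nothing shown here explains why this one change lowers the number. For the compounds shown here, with only one pair at this position, it remains open how a carboxylic acid, an aminomethyl group or a longer chain such as hydroxyethyl would behave there, and whether the same swap of ester for alcohol would give a similar step on a different core, such as the one in compound 3.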